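The source may hold more compounds than are shown below. What is called first, only, known or untested is meant among the compounds shown, and "the series" means these compounds.

Measured so far in this series:
compound 1, `COC(=O)CCCc1onc(NS(=O)(=O)c2ccc(C(C)(C)C)cc2)c1Sc1cccc(OC)c1`, 310 nM;
compound 2, `COc1cccc(Sc2c(NS(=O)(=O)c3ccc(C(C)(C)C)cc3)noc2CCCCC=O)c1`, 20 nM.

Among the compounds with values here, in an assay on COS-7 cells for displacement of a labelled ligand from Endothelin receptor type B (Sus scrofa) (on this read-out lower numbers stand for stronger inhibition and higher numbers for weaker inhibition), compound 2 holds the lower of the two numbers; the single measured step, a 16-fold lower number from compound 1 to compound 2 (1.19 log units; beyond the scatter), leads to it, and it is large.

Compound 3 is `COc1cccc(Sc2c(NS(=O)(=O)c3ccc(C(C)(C)C)cc3)noc2CCC/C=N/O)c1`. It differs from compound 2 by a group of 3 heavy atoms (1 carbon, 1 nitrogen, 1 oxygen; no ring) in place of a group of 3 heavy atoms (2 carbon, 1 oxygen; no ring), on a saturated chain carbon, three bonds along the chain from an aromatic carbon; the leaving group is formylmethyl, the entering group carries one hydrogen-bond donor and two hydrogen-bond acceptors where the leaving group carried none and one, and both keep one double bond outside aromatic rings.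

Within the data shown here, the only step that bears on this position is a 16-fold lower number from compound 1 to compound 2 (1.19 log units; beyond the scatter), and it exchanged methoxycarbonyl for formylmethyl rather than touching the present pair of groups. Among the measured compounds shown here, no measured step shows what the present exchange does. The expectation is therefore a step of no more than modest size, a 2.0-fold higher number from compound 2 to compound 3 (0.30 log units; within the scatter), most likely within the scatter or a small rise in the number. For compound 3 the estimate in this assay is 40 nM, with a range from 10 nM to 160 nM.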

Compound 3, half-maximal inhibitory concentration: 85 nM
For compound 3 the middle estimate is 2.1-fold (0.33 log units) below the measured one; low and high end bracket the measured number.
By their numbers in this assay, from the lowest: compound 2; then compound 3; then compound 1.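

In this assay, the end of this chain proves sensitive a second time: the exchange of formylmethyl for the group with one carbon, one nitrogen and one oxygen gives a 4.3-fold higher number from compound 2 to compound 3 (0.63 log units; beyond the scatter) and so gives back part of the earlier gain. Read against the ester end, the new group still gives a 3.6-fold lower number from compound 1 to compound 3 (0.56 log units; beyond the scatter) and thus takes the middle place, with all three end groups printed apart beyond the scatter and formylmethyl holding the lowest number. No measurement available here accounts for this order.

Going by these compounds, it remains open whether a primary alcohol, a carboxylic acid or an amine at this chain end would match formylmethyl or fall towards methoxycarbonyl. Also open, on these data alone, is whether a shorter or longer chain would keep the number of compound 2.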